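The compounds below may be only part of what the source reports. "The series", "measured", "known", "first", "only" and "open" are said of these compounds alone.

Measured so far in a functional assay on HepG2 cells (Homo sapiens) for cytotoxicity, read by MTT assay, with a stated time of 72 h; a lower number here means a stronger inhibitor, a higher number a weaker inhibitor:
- compound 1 `Cc1cc(=O)n(-c2ccccc2OC(F)(F)F)nc1C(=O)Nc1ccc(Oc2ncnc3ccsc23)cc1` gives 25000 nM
- compound 2 `Cc1cc(=O)n(-c2ccccc2OC(F)(F)F)nc1C(=O)Nc1ccc(Oc2ncnc3ccsc23)c(F)c1` gives 15700 nM
- compound 3 `Cc1cc(=O)n(-c2cccc(F)c2)nc1C(=O)Nc1ccc(Oc2ncnc3ccsc23)c(F)c1` gives 7810 nM

Compound 2 stands second highest of the three numbers. Its nearest neighbour is compound 1, and the step of a 1.6-fold lower number from compound 1 to compound 2 (0.20 log units; within the scatter) lies within the scatter. Its furthest neighbour is compound 3, and the step of a 2.0-fold lower number from compound 2 to compound 3 (0.30 log units; within the scatter) also lies within the scatter. On these numbers the three compounds cannot be ordered.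

Compound 4 `Cc1cc(=O)n(-c2ccccc2OC(F)(F)F)nc1C(=O)Nc1ccc(Oc2ncnc3sccc23)c(F)c1` is not yet measured. It differs from compound 2 only in the bicyclic group on the ether oxygen: a group of 9 heavy atoms (6 carbon, 2 nitrogen, 1 sulfur; one five-membered aromatic ring with 1 hetero atom, one six-membered aromatic ring with 2 hetero atoms) in place of a group of 9 heavy atoms (6 carbon, 2 nitrogen, 1 sulfur; one five-membered aromatic ring with 1 hetero atom, one six-membered aromatic ring with 2 hetero atoms), on an oxygen on an aromatic ring. The two groups contain the same atoms joined differently.

Neither measured step touches this part of the molecule: one exchanges hydrogen for fluoro on an aromatic carbon, the other exchanges the aryl group on the aromatic nitrogen. Both were within the scatter, and no comparison involving the bicyclic group exists in this set. The expectation for compound 4 therefore rests on compound 2 alone, and no step beyond the scatter is expected in this assay in either direction.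

The estimated step is a 1.0-fold lower number from compound 2 to compound 4 (0.02 log units; within the scatter), which is expected to stay within the scatter. For compound 4 the estimate in this assay is 15000 nM, with an expected range from 6000 nM to 40000 nM.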

Compound 4, half-maximal inhibitory concentration: > 40000 nM
Compound 4: only a limit was reported; the forecaster's own chance of this, stated with the estimate: 15%; at least 2.6-fold (0.42 log units) between middle value and limit.
By their numbers in this assay, from the lowest: compounds 3, 2 and 1 (each within the scatter of the next, the first and the last beyond it). At a limit, above all of these: compound 4.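

In this assay, exchanging the group on the oxygen on an aromatic ring for one with the same atoms joined differently gives an at least 2.5-fold higher number from compound 2 to compound 4 (0.40 log units; beyond the scatter). The counts of atoms, rings, hydrogen-bond donors and acceptors and the net charge are identical in the two groups. The two groups differ only in how their atoms are joined, and no earlier comparison tested such a difference. The two earlier steps, fluoro in place of hydrogen and 3-fluorophenyl in place of 2-(trifluoromethoxy)phenyl, stayed within the scatter, making this the only one of the three changed places with a step beyond it, although the value of compound 4 is a limit and not a number: the limit of > 40000 nM in this assay, at which 1 of the 4 values shown sits.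

On these data alone, this rests on a single pair, so it remains open whether the same exchange has a comparable effect when the aromatic nitrogen carries 3-fluorophenyl, as in compound 3, or when the fluoro is absent, as in compound 1. Also open, as far as these compounds go, is how an amine or a methoxy group on either bicyclic group would behave, and whether the step extends beyond this one cell line.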